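Fluorine on a Phenyl Ring and Cell Toxicity

A few compounds are considered here, and "the series" means these few. Any claim that something is new, unique, unknown or untested is made for them only; others in the source may bear on it.

Compound 1 `Fc1ccc2nc(-c3cc(-c4ccccc4)nn3-c3ccccc3)ccc2c1` and compound 2 `Fc1ccc(-n2nc(-c3ccccc3)cc2-c2ccc3cc(F)ccc3n2)cc1` differ only by fluoro in place of hydrogen on an aromatic carbon. In an ADME assay on Huh-7 cells (Homo sapiens) for cytotoxicity, read by XTT assay, with a stated time of 3 days, tested at 20 uM (on this read-out higher numbers stand for a weaker effect at the one concentration tested and lower numbers for a stronger effect), compound 1 gives 126%, and compound 2 gives 97.8%, a step that reads a number 28.2 percentage points lower from compound 1 to compound 2 (beyond the scatter). Compound 3 `COc1ccc(-n2nc(-c3ccccc3)cc2-c2ccc3cc(F)ccc3n2)cc1` has a different core than compound 1, the difference being (methoxy in place of hydrogen on an aromatic carbon); in this assay compound 3 gives 116%, which is a number 10 percentage points lower from compound 1 to compound 3 (within the scatter). Compound 4 `COc1ccc(-n2nc(-c3ccc(F)cc3)cc2-c2ccc3cc(F)ccc3n2)cc1` differs from compound 3 by fluoro in place of hydrogen on an aromatic carbon, the same change as that from compound 1 to compound 2, occurring twice among these compounds. The expected step is a number 26 percentage points lower from compound 3 to compound 4 (beyond the scatter), because the same change earlier gave a number 28.2 percentage points lower from compound 1 to compound 2 (beyond the scatter). Compound 4 is therefore estimated at 90% in this assay, with a likely range from 70% to 112%.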

Compound 4, a percentage reported as activity, at one concentration (the size of the read-out at that concentration, not a potency): 89.1%
Compound 4: the middle estimate sits 0.9 percentage points above what was measured; the range from low to high includes it.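

In this assay, putting fluoro in place of hydrogen, phenyl to 4-fluorophenyl, gives a number 26.9 percentage points lower from compound 3 to compound 4 (beyond the scatter). Set beside the earlier step, the change carries over from one core to the other at much the same size: the same change on two cores in this assay, a number 28.2 percentage points lower (beyond the scatter) from compound 1 to compound 2 and a number 26.9 percentage points lower (beyond the scatter) from compound 3 to compound 4, 1.3 percentage points apart, within the scatter of two such steps. Among these compounds, this rests on only two pairs, so it does not show that the step would hold on any other core, and it does not explain why the number falls.

The compounds shown leave open whether an amine or a carboxylic acid in place of that hydrogen would shift the number in the same way. They also leave open how chloro would behave there.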